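The compounds below may be only part of what the source reports. "The series", "measured", "known", "first", "only" and "open" are said of these compounds alone.

In a functional assay on CHO-K1 cells for antagonist activity at prostaglandin D2 receptor 2 (Homo sapiens), read by scintillation counting and GTPgammaS binding, with stated times of 1 h and 2 h (a higher number here means a weaker inhibitor, a lower number a stronger inhibitor), compound 1 `Cc1c(CC(=O)O)c(-c2ccccc2)nn1Cc1ccccc1CS(=O)(=O)c1ccccc1` gives 490 nM. Compound 2 `Cc1c(CC(=O)O)c(-c2ccccc2)nn1Cc1ccccc1S(=O)(=O)N1CCCCC1`, which carries a (piperidin-1-yl)sulfonyl group in place of the (phenylsulfonyl)methyl group on an aromatic carbon, gives 66 nM. Among the compounds with values here, that is the only measured step here: a 7.4-fold lower number from compound 1 to compound 2 (0.87 log units; beyond the scatter). Compound 2 thus has the lower of the two numbers, and its gap to compound 1 lies beyond the scatter. Compound 3 `Cc1c(CC(=O)O)c(-c2ccccc2)nn1Cc1ccccc1S(=O)(=O)N(C)C` has not yet been measured. It differs from compound 2 by dimethylamino in place of piperidin-1-yl on a sulfonyl sulfur. Within the data shown here, the one measured step swapped two quite different groups on the aromatic carbon, whereas here the sulfonyl stays and only the group on its sulfur changes, so no measured step directly covers this change. With nothing pointing to a large shift, compound 3 is expected to stay near compound 2 in this assay. The expected step is a 1.8-fold higher number from compound 2 to compound 3 (0.26 log units; within the scatter), within or close to the scatter. Compound 3 is therefore estimated at 120 nM, within 40 nM to 350 nM.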

Compound 3, half-maximal inhibitory concentration: 850 nM
For compound 3 the middle estimate is 7.1-fold (0.85 log units) below the measured one, outside the stated range (above it).
By their numbers in this assay, from the lowest: compound 2; then compounds 1 and 3 (each within the scatter of the next).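

Up to now, only a swap of the whole group on the aromatic carbon had been seen; this result shows that, with the sulfonyl kept, the group on its sulfur alone matters greatly in this assay. Replacing piperidin-1-yl with dimethylamino gives a 13-fold higher number from compound 2 to compound 3 (1.11 log units; beyond the scatter), and dimethylsulfamoyl in place of (phenylsulfonyl)methyl gives a 1.7-fold higher number from compound 1 to compound 3 (0.24 log units; within the scatter), so the low number of compound 2 depends on piperidin-1-yl and not on a sulfonyl attached directly to the aromatic carbon. No supporting evidence explains why these two groups differ so strongly.

The compounds shown leave open whether the ring or simply the number of carbons matters. Diethylamino and pyrrolidin-1-yl on the same sulfur would help separate these two readings, while morpholin-4-yl would show how a ring oxygen is tolerated there.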